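The compounds below may be only part of what the source reports. "The series", "measured", "known", "first", "only" and "open" are said of these compounds alone.

In a functional assay on DU-145 cells (Homo sapiens) for inhibition, read by CCK-8 assay, with a stated time of 72 h (on this read-out lower numbers stand for stronger inhibition and higher numbers for weaker inhibition), compound 1 `O=C(/C=C/c1cccnc1)NCCCCCCc1cccc(S(=O)(=O)Nc2ccccc2)c1` gives 6.73 nM, compound 2 `Cc1ccc(NS(=O)(=O)c2cccc(CCCCCCNC(=O)/C=C/c3cccnc3)c2)cc1` gives 34.4 nM and compound 3 `CCc1ccc(NS(=O)(=O)c2cccc(CCCCCCNC(=O)/C=C/c3cccnc3)c2)cc1` gives 40.1 nM. Compound 3 therefore stands level with compound 2, and both are weaker than compound 1. Compound 4 `CC(C)(C)c1ccc(NS(=O)(=O)c2cccc(CCCCCCNC(=O)/C=C/c3cccnc3)c2)cc1` differs from compound 3 by tert-butyl in place of ethyl on an aromatic carbon, which is tert-butyl in place of ethyl on an aromatic carbon. The nearest evidence is the methyl-to-ethyl comparison, a 1.2-fold higher number from compound 2 to compound 3 (0.07 log units; within the scatter), which shows no real change. The larger losses came with the first substituent, a 5.1-fold higher number from compound 1 to compound 2 (0.71 log units; beyond the scatter) and a 6.0-fold higher number from compound 1 to compound 3 (0.78 log units; beyond the scatter). Only a small weakening in this assay is therefore expected, possibly inside the scatter, and the expected step is a 1.4-fold higher number from compound 3 to compound 4 (0.14 log units; within the scatter). For compound 4 the estimated value is 55 nM, with an expected range of 20 nM to 150 nM.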

Compound 4, half-maximal inhibitory concentration: 281 nM
Estimate against measurement, compound 4: 5.1-fold (0.71 log units) below; the measured number lies above the stated range.
By their numbers in this assay, from the lowest: compound 1; then compounds 2 and 3 (each within the scatter of the next); then compound 4.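

In this assay the place para to a large group does not stay flat as the substituent grows: methyl and ethyl lie within the scatter of each other, whereas tert-butyl gives a 7.0-fold higher number from compound 3 to compound 4 (0.85 log units; beyond the scatter) and an 8.2-fold higher number from compound 2 to compound 4 (0.91 log units; beyond the scatter). Going by these compounds alone, measured against hydrogen, the same group gives a 42-fold higher number from compound 1 to compound 4 (1.62 log units; beyond the scatter) and the only step here graded large. No measurement at hand accounts for this loss.

Ethyl and tert-butyl differ in both carbon count and branching, so isopropyl or a straight butyl chain would be needed to separate the two. From the compounds shown here alone, how an amine or a carboxylic acid would behave at this place remains open.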